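The compounds below may be only part of what the source reports. "The series", "measured", "known", "first", "only" and "open" are said of these compounds alone.

Measured so far in a functional assay on A549 cells (Homo sapiens) for antiproliferative activity, read by MTT assay, with a stated time of 48 h; on this read-out lower numbers stand for stronger inhibition and higher numbers for weaker inhibition:

Compound 1, `N#CC1=C(N)Oc2c(c3nc4ccccc4nc3c3ccccc23)C12C(=O)N(Cc1cnnn1-c1ccccc1Cl)c1ccccc12`, gives 42600 nM.
Compound 2, `N#CC1=C(N)Oc2c(c3nc4ccccc4nc3c3ccccc23)C12C(=O)N(Cc1cnnn1-c1ccc(S(N)(=O)=O)cc1)c1ccccc12`, returns only the assay limit > 50000 nM.
Compound 3, `N#CC1=C(N)Oc2c(N)cc3nc4ccccc4nc3c2C12C(=O)N(Cc1cnnn1-c1ccc(Cl)cc1)c1ccccc12`, also returns only the assay limit > 50000 nM.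

Compound 3 therefore has no number of its own in this assay; it sits at the limit, as do two of the three values shown (the limit of > 50000 nM in this assay, at which 2 of the 3 values shown sit). Among the compounds with values here, compound 1 is the only member of the series with a measured number, and it is a weak one.

Compound 4, `COc1ccc(-n2nncc2CN2C(=O)C3(C(C#N)=C(N)Oc4c(N)cc5nc6ccccc6nc5c43)c3ccccc32)cc1`, is not yet measured. It is built from compound 3 by methoxy in place of chloro on an aromatic carbon, the aryl group on the triazole nitrogen going from 4-chlorophenyl to 4-methoxyphenyl.

Within the data shown here, only one measured step exists, an at least 1.1-fold higher number from compound 1 to compound 2 (0.06 log units; that floor lies within the scatter), and it swaps a different aryl substituent while starting from a compound that carries a measured number; it stays within the scatter. Among the measured compounds shown here, no measured step covers methoxy in place of chloro, and none starts from a compound already at the limit. The expectation for compound 4 is therefore that a step that the limit leaves unreadable from compound 3 to compound 4 amounts to nothing beyond the scatter. Compound 4 is estimated at 60000 nM in this assay, with a range of 30000 nM to 120000 nM, and most likely another limit rather than a number.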

Compound 4, half-maximal inhibitory concentration: > 50000 nM
Compound 4: only a limit was reported; the forecaster's own chance of this, stated with the estimate: 75%; the middle value lies beyond the limit too.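

Compound 3 and compound 4 both stop at a limit in this assay, so no step can be read for 4-methoxyphenyl in place of 4-chlorophenyl, and compound 4 joins the compounds at that limit: the limit of > 50000 nM in this assay, at which 3 of the 4 values shown sit.

The compounds shown leave open whether these two aryl groups differ at all on this core, as neither compound carries a number.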